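Ester to acid: a one-bond change in a leukotriene antagonist

A few compounds are considered here, and "the series" means these few. Any claim that something is new, unique, unknown or untested is made for them only; others in the source may bear on it.

Measured so far:
Compound 1, `O=C(O)CCCOc1cccc(/C=C/c2ccc3cc(Cl)ccc3n2)c1`, in a functional assay on lung (Cavia porcellus) for binding affinity to cysteinyl leukotriene receptor (Homo sapiens) (a lower number here means a stronger inhibitor, a higher number a weaker inhibitor), compound 1 gives 270 nM.
Compound 2, `CCOC(=O)CCCOc1cccc(/C=C/c2ccc3ccccc3n2)c1`, in this assay compound 2 gives 580 nM.

For the measured compounds named here, compound 2 stands at the higher of the two numbers known in this assay, so it is the weaker of the two; compound 1 sits at the lower number, and the gap between them is beyond the usual scatter.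

Compound 3, `O=C(O)CCCOc1cccc(/C=C/c2ccc3ccccc3n2)c1`, has not yet been measured. It differs from compound 2 in one place: hydrogen in place of ethyl on an oxygen next to a carbonyl group. Compound 3 thus carries the same acid end as compound 1 while keeping the core of compound 2.

Going by the values given here, no measured pair in this set shows the ester-to-acid step by itself, so its size cannot be read directly. Still, compound 1, which also carries the free acid, gives 270 nM in this assay, and on that basis compound 3 is expected to land at a lower number than compound 2, with a step from ester to acid estimated as a 1.9-fold lower number from compound 2 to compound 3 (0.29 log units; within the scatter). For compound 3 the estimated value in this assay is 300 nM, with a range from 100 nM to 1000 nM.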

Compound 3, half-maximal inhibitory concentration: 480 nM
Beside the measured number, compound 3's estimate is 1.6-fold (0.20 log units) below it; the measured number falls inside the stated range.
By their numbers in this assay, from the lowest: compounds 1, 3 and 2 (each within the scatter of the next, the first and the last beyond it).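

Read on its own for the first time in this assay, the change from ethyl to hydrogen on an oxygen next to a carbonyl group gives a small step (a 1.2-fold lower number from compound 2 to compound 3 (0.08 log units; within the scatter)), so in this assay the ethyl ester and the free carboxylic acid cannot be told apart on this core. The second single change, hydrogen in place of chloro on an aromatic carbon, also stays small (a 1.8-fold higher number from compound 1 to compound 3 (0.25 log units; within the scatter)), so neither of these two one-place changes alone moves the number beyond what repeated measurements would scatter by. No measurement in hand offers an explanation for the size of either step.

The compounds shown leave open how a different group at the acid end would behave, such as a primary amide or a tetrazole, and whether a shorter or longer chain leading to that end would give a step beyond the scatter. They also leave open what a fluoro, methyl or methoxy group would do on the aromatic carbon that carries chloro in compound 1, and whether an ester of the chloro compound would follow the same small step.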